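A few compounds are considered here, and "the series" means these few. Any claim that something is new, unique, unknown or untested is made for them only; others in the source may bear on it.

Measured so far:
compound 1, `Cc1cc(=O)c2c(O)cc(OCc3ccc([N+](=O)[O-])cc3)c([C@H]3CCN(C)C[C@H]3O)c2o1` — 39%
compound 2, `CCOC(=O)N1CCN(Cc2c(O)c([C@H]3CCN(C)C[C@H]3O)c3oc(C)cc(=O)c3c2O)CC1` — 31%
compound 3, `Cc1oc2c([C@H]3CCN(C)C[C@H]3O)c(O)cc(O)c2c(=O)c1C(O)c1cccc(Cl)c1` — 5%

All three were tested in a functional assay on MCF7 cells (Homo sapiens) for inhibition, read by MTT assay, with a stated time of 48 h, tested at 10 uM; on this read-out higher numbers stand for more inhibition of growth at the one concentration tested and lower numbers for less inhibition of growth. On these numbers compound 3 stands lowest. Its nearest neighbour is compound 2, which gives 31%, a number higher by a margin beyond the usual scatter; furthest away is compound 1, which gives 39%, also beyond the scatter. Within the data shown here, no two of the measured compounds differ in just one place, so no single structural step has yet been tied to a change in growth inhibition.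

Compound 4, `Cc1oc2c([C@H]3CCN(C)C[C@H]3O)c(O)cc(O)c2c(=O)c1C(O)c1cccc(Cl)c1Cl`, has not been measured. It differs from compound 3 by one change: chloro in place of hydrogen on an aromatic carbon. The entering chloro sits ortho to a chloro group and ortho to a large group on the 3-chlorophenyl ring, making it a 2,3-dichlorophenyl ring.

Among the measured compounds shown here, with no comparable step among the measured compounds, the expectation rests on the small size of the change. The step of a number 7 percentage points higher from compound 3 to compound 4 (within the scatter) is expected to be modest, pointing slightly upward, and quite possibly within the scatter. Compound 4 is therefore expected to give about 12%, with a range from 0% to 30%.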

Compound 4, percent growth inhibition at one concentration: 7%
For compound 4 the middle estimate is 5 percentage points above the measured one; low and high end bracket the measured number.
By their numbers in this assay, from the lowest: compounds 3 and 4 (each within the scatter of the next); then compounds 2 and 1 (each within the scatter of the next).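

Among these compounds, this is the first pair in the set that differs in just one place, which gives the first structural step that can be read in this assay at all. Chloro in place of hydrogen on the aromatic carbon, ortho to a chloro group and ortho to a large group, turns 3-chlorophenyl into 2,3-dichlorophenyl and gives a number 2 percentage points higher from compound 3 to compound 4 (within the scatter), so at this position, at the one concentration tested, a second chloro makes no difference that can be told from the scatter. No measurement is at hand that would explain this result.

On these data alone, it stays open whether a different group at this same place, such as a methoxy group, an amine or a carboxylic acid, would move growth inhibition beyond the scatter, as a single chloro on a single ring says little about the position as a whole. The compounds shown also include no plain phenyl ring at this place, so the part played by the chloro already present on the ring cannot be read either.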